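Methoxy in Place of Hydrogen: Expecting the Next Number

The compounds below may be only part of what the source reports. "The series", "measured", "known", "first", "only" and "open" are said of these compounds alone.

Compound 1, `O=C(CCCc1nc2ccccc2c(=O)[nH]1)N/N=C/c1ccc(O)c(O)c1`, gives 75000000 nM in a physicochemical assay, read by spectrophotometry, with a stated time of 15 min; on this read-out lower numbers stand for stronger inhibition and higher numbers for weaker inhibition.
Compound 2, `COc1cc(/C=N/NC(=O)CCCc2nc3ccccc3c(=O)[nH]2)ccc1O`, gives 280000000 nM in this assay.

Within the data shown here, compound 2 stands highest of the two numbers so far, and the single measured step, a 3.7-fold higher number from compound 1 to compound 2 (0.57 log units; beyond the scatter), lies beyond the scatter. Compound 3, `COc1cc(/C=N/NC(=O)CCCc2nc3ccccc3c(=O)[nH]2)cc(OC)c1O`, has not yet been measured. It differs from compound 2 in one place: methoxy in place of hydrogen on an aromatic carbon.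

Among the measured compounds shown here, the only step that bears on this change is a 3.7-fold higher number from compound 1 to compound 2 (0.57 log units; beyond the scatter), where a methyl in place of hydrogen on an oxygen of the same ring raised the number modestly. The new change again brings a methoxy onto that ring, though here in place of a hydrogen on an aromatic carbon, so a modest step in the same direction is expected, a 2.1-fold higher number from compound 2 to compound 3 (0.33 log units; beyond the scatter). Compound 3 is therefore estimated at 600000000 nM, within a range from 250000000 nM to 1500000000 nM.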

Compound 3, half-maximal inhibitory concentration: 225000000 nM
The estimate for compound 3 lay 2.7-fold (0.43 log units) above the measured number; the whole stated range lies above it.
By their numbers in this assay, from the lowest: compound 1; then compounds 3 and 2 (each within the scatter of the next).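

At this position, an aromatic carbon ortho to a hydroxy group, methoxy in place of hydrogen gives a 1.2-fold lower number from compound 2 to compound 3 (0.09 log units; within the scatter) in this assay, so compound 3 cannot be told apart from compound 2 on this read-out. The earlier step, a 3.7-fold higher number from compound 1 to compound 2 (0.57 log units; beyond the scatter), came from a methyl placed on an oxygen of the same ring, so the two changes do not read alike, and bringing a methoxy onto this ring does not by itself carry a step beyond the scatter. Nothing available explains why these two changes differ.

The compounds shown compare only hydrogen and methoxy at this carbon, so it remains open whether an amine, a carboxylic acid or a longer chain there would shift the number beyond the scatter. From the compounds shown here alone, it is also open whether methoxy would read the same way on a ring without the hydroxy group.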